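Swapping the chloromethylphenyl on a triazole-bearing spiro core

The source may hold more compounds than are shown below. What is called first, only, known or untested is meant among the compounds shown, and "the series" means these compounds.

Measured compounds:
Compound 1 `Cc1ccc(-n2nncc2CN2C(=O)C3(C(C#N)=C(N)Oc4c3c3nc5ccccc5nc3c3ccccc43)c3ccccc32)cc1Cl`; in a functional assay on A549 cells (Homo sapiens) for antiproliferative activity, read by MTT assay, with a stated time of 48 h (on this read-out higher numbers stand for weaker inhibition and lower numbers for stronger inhibition), compound 1 gives > 50000 nM, which is a limit of the assay.
Compound 2 `Cc1ccc(Cl)cc1-n1nncc1CN1C(=O)C2(C(C#N)=C(N)Oc3c2c2nc4ccccc4nc2c2ccccc32)c2ccccc21`; in this assay compound 2 gives > 50000 nM, also a limit of the assay.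
Compound 3 `Cc1ccc(-n2nncc2CN2C(=O)C3(C(C#N)=C(N)Oc4c(N)cc5nc6ccccc6nc5c43)c3ccccc32)cc1Cl`; in this assay compound 3 gives 11800 nM.

Compounds 1 and 2 share one core and differ only in the change (5-chloro-2-methylphenyl in place of 3-chloro-4-methylphenyl on an aromatic nitrogen). The step that the two limits leave unreadable from compound 1 to compound 2 cannot be read because of the limit of > 50000 nM in this assay, at which 2 of the 3 values shown sit. Compound 3 is built on a second core; the difference between the two cores is not broken down here. Compound 4 `Cc1ccc(Cl)cc1-n1nncc1CN1C(=O)C2(C(C#N)=C(N)Oc3c(N)cc4nc5ccccc5nc4c32)c2ccccc21` has not yet been measured. It differs from compound 3 by 5-chloro-2-methylphenyl in place of 3-chloro-4-methylphenyl on an aromatic nitrogen, the same change as between compounds 1 and 2, placed at the same point of the triazole ring. That earlier step gives no readable size, so the expectation for compound 4 rests on compound 3 giving 11800 nM in this assay, with a wide allowance either way. Compound 4 is expected to give about 16000 nM, estimated between 5000 nM and 50000 nM. The expected step of a 1.4-fold higher number from compound 3 to compound 4 (0.13 log units; within the scatter) is thus small, but it is only an estimate.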

Compound 4, half-maximal inhibitory concentration: > 50000 nM
Compound 4: a limit, no number (the forecaster's own chance of this, stated with the estimate: 35%); at least 3.1-fold (0.49 log units) between middle value and limit.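

In this assay, placing 5-chloro-2-methylphenyl in place of 3-chloro-4-methylphenyl on the core of compound 3 gives an at least 4.2-fold higher number from compound 3 to compound 4 (0.62 log units; beyond the scatter), so on this core the swap weakens inhibition by more than the usual scatter of repeated measurements. As far as these compounds go, compound 4 gives > 50000 nM, which is a limit of the assay and not a number, so the full size of this step stays unknown. The same change on the core of compound 1 cannot be read, and the series therefore cannot show whether the change has the same effect on both cores: the limit of > 50000 nM in this assay, at which 3 of the 4 values shown sit.

From the compounds shown here alone, it remains open whether the chlorine, the methyl or the arrangement of the two accounts for the difference on the core of compound 3. A plain phenyl, or a phenyl carrying only a methyl or only a chlorine, would be needed on that core to separate these possibilities.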